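The compounds below may be only part of what the source reports. "The series", "measured", "known", "first", "only" and "open" are said of these compounds alone.

Measured compounds:
- compound 1, `O/N=C1/C(c2c[nH]c3ccc(OCc4ccccc4)cc23)=Nc2ccc(OCc3ccccc3)cc21`: 11800 nM
- compound 2, `c1ccc(CO/N=C2/C(c3c[nH]c4ccccc34)=Nc3ccccc32)cc1`: 12200 nM

Both numbers come from a functional assay on T-24 cells (Homo sapiens) for cytotoxicity, read by MTT assay, with a stated time of 2 days (on this read-out lower numbers stand for stronger inhibition and higher numbers for weaker inhibition), and the two compounds share the same core, differing only in the benzyloxy groups carried by compound 1. In this assay, going by the values given here, compound 2 gives 12200 nM, and in the same assay compound 1 gives 11800 nM; the gap between these two numbers falls within the scatter, so nothing separates compound 2 from compound 1 on the evidence so far, and compound 2 stands level with the only other member of the series.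

Compound 3, `Fc1ccc(CO/N=C2/C(c3c[nH]c4ccccc34)=Nc3ccccc32)cc1`, is not yet measured. Relative to compound 2 it carries fluoro in place of hydrogen on an aromatic carbon. Among the compounds with values here, no pair of measured compounds differs in one place, so the series gives no step from which to read the size of such a change. The expectation for this assay is therefore a step no larger than the scatter, in no settled direction, with the number staying close to that of compound 2. Compound 3 is estimated at 10500 nM, within a range from 4000 nM to 28000 nM. The expected step is a 1.2-fold lower number from compound 2 to compound 3 (0.07 log units; within the scatter).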

Compound 3, half-maximal inhibitory concentration: 23100 nM
The estimate for compound 3 lay 2.2-fold (0.34 log units) below the measured number; the range from low to high includes it.
By their numbers in this assay, from the lowest: compounds 1, 2 and 3 (each within the scatter of the next).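

Going by these compounds alone, compound 3 supplies the first one-place step: in this assay, fluoro in place of hydrogen on an aromatic carbon, reading as benzyl to 4-fluorobenzyl, gives a 1.9-fold higher number from compound 2 to compound 3 (0.28 log units; within the scatter). At this place, para to a large group, the single fluoro therefore does not separate compound 3 from compound 2 on this read-out, and this one step fixes no direction for the change. The compounds shown offer nothing that bears on this result.

Still open, going by these compounds, is whether a different group on the same aromatic carbon, such as an amine, a carboxylic acid or a methoxy group, or a longer chain in place of the benzyl, would give a step beyond the scatter. Within the data shown here, compound 1 and compound 2 differ in more than one place, so the separate contribution of each benzyloxy group in compound 1 cannot be read, and a version of the shared core carrying only one of those groups would be needed to separate them.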